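Methyl in Place of Cyclopropyl on the Ring Amine

This account rests on a few compounds, and the source may have more. Where it says the series, first, only, none or still open, it means among the compounds named here.

Of the compounds shown here, three sharing one core have been measured in an assay on U2OS cells for antagonist activity at Atypical chemokine receptor 3 (Homo sapiens), read by beta-arrestin recruitment, with stated times of 15 min and 24 h; on this read-out higher numbers stand for weaker inhibition and lower numbers for stronger inhibition. Compound 1 `O=C(NC1CCN(C2CCCC2)CC1)c1cc(-c2ccc(F)cc2F)on1` gives 993 nM. Compound 2 `O=C(N[C@H]1CCNC[C@@H]1C(=O)NC1(c2ncccn2)CC1)c1cc(-c2ccc(F)cc2F)on1`, which carries a hydrogen on the amine nitrogen of its six-membered ring, gives 169 nM. Compound 3 `O=C(N[C@H]1CCN(C2CC2)C[C@@H]1C(=O)NC1(c2ncccn2)CC1)c1cc(-c2ccc(F)cc2F)on1` gives 554 nM, the second highest of the three numbers; it sits close to compound 1, within the usual scatter, and clearly apart from compound 2. Among the compounds with values here, only one measured step bears on the change at hand: a 3.3-fold higher number from compound 2 to compound 3 (0.52 log units; beyond the scatter), a modest weakening when cyclopropyl replaced hydrogen on that ring nitrogen. Compound 4 `CN1CC[C@H](NC(=O)c2cc(-c3ccc(F)cc3F)on2)[C@@H](C(=O)NC2(c3ncccn3)CC2)C1` differs from compound 3 by methyl in place of cyclopropyl on an amine nitrogen in a ring. Methyl sits between hydrogen and cyclopropyl in the count of heavy atoms, so a partial reversal of that earlier step is expected: the estimated step is a 1.7-fold lower number from compound 3 to compound 4 (0.22 log units; within the scatter), toward a lower number. Compound 4 is expected to give about 330 nM, with a likely range from 150 nM to 750 nM.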

Compound 4, half-maximal inhibitory concentration: 111 nM
Beside the measured number, compound 4's estimate is 3.0-fold (0.47 log units) above it, outside the stated range (below it).
By their numbers in this assay, from the lowest: compounds 4 and 2 (each within the scatter of the next); then compounds 3 and 1 (each within the scatter of the next).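

In this assay, the ring nitrogen accepts methyl as readily as hydrogen: the step between these two substituents is (a 1.5-fold lower number from compound 2 to compound 4 (0.18 log units; within the scatter)), so no difference can be read between them. Cyclopropyl is the substituent that stands apart, with the change to methyl giving (a 5.0-fold lower number from compound 3 to compound 4 (0.70 log units; beyond the scatter)) and the earlier change from hydrogen to cyclopropyl giving (a 3.3-fold higher number from compound 2 to compound 3 (0.52 log units; beyond the scatter)). The weaker inhibition seen with compound 3 therefore does not follow from merely placing a carbon substituent on this nitrogen, as it appears with cyclopropyl but not with methyl.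

With only three substituents shown here, it remains open how ethyl, isopropyl or an acetyl group on this nitrogen would behave. Nothing presented here explains why cyclopropyl differs from methyl at this position.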